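A few compounds are considered here, and "the series" means these few. Any claim that something is new, unique, unknown or untested is made for them only; others in the source may bear on it.

Compound 1 `Cc1ccc2ccccc2c1N1CC(=O)N(Cc2ccc(C(=O)NO)cc2)C1=O` gives 13.1 nM.
Compound 2 `Cc1ccc(CC2(c3ccccc3)NC(=O)N(Cc3ccc(C(=O)NO)cc3)C2=O)cc1` gives 82.4 nM.

Of the two compounds measured in an assay on isolated protein for inhibition of protein deacetylase HDAC6 (Homo sapiens), read by fluorescence, with stated times of 10 min and 2 h (a lower number here means a stronger inhibitor, a higher number a weaker inhibitor), compound 2 shows the higher number, and compound 1 stands below it by a margin beyond the scatter. Compound 3 `O=C(NO)c1ccc(CN2C(=O)NC(Cc3ccc4ccccc4c3)(c3ccccc3)C2=O)cc1` is the unmeasured companion of compound 2 and differs from it in one place: naphthalen-2-yl in place of 4-methylphenyl on a saturated chain carbon bound to a saturated ring carbon. Within the data shown here, no measured pair isolates this change, so its effect is not yet known. In this assay the step of a 1.4-fold lower number from compound 2 to compound 3 (0.14 log units; within the scatter) is expected to be small, toward a lower number, and within the scatter. Compound 3 is therefore estimated at 60 nM, with a range of 25 nM to 150 nM.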

Compound 3, half-maximal inhibitory concentration: 74.6 nM
Compound 3: middle estimate off by 1.2-fold (0.09 log units), on the low side; the range from low to high includes it.
By their numbers in this assay, from the lowest: compound 1; then compounds 3 and 2 (each within the scatter of the next).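

In this assay the step of a 1.1-fold lower number from compound 2 to compound 3 (0.04 log units; within the scatter) lies within the scatter. On a saturated chain carbon bound to a saturated ring carbon, this position thus takes naphthalen-2-yl, with its second six-membered aromatic ring of carbon only, in place of 4-methylphenyl without a readable shift in the number. Nothing shown gives a reason for this. Still open, from the compounds shown here alone, is whether a group of another kind at this place, such as an amine or a carboxylic acid, would shift the number. A longer chain carrying the naphthalen-2-yl group is equally untested here.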